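This account rests on a few compounds, and the source may have more. Where it says the series, first, only, none or still open, it means among the compounds named here.

Measured so far in an assay on isolated protein for activation of cGMP-dependent protein kinase 1 (Homo sapiens), read by ADP-Glo, with stated times of 30 min and 2 h, in the presence of a further agent that is not named here; on this read-out higher numbers stand for an effect only at larger amounts of compound and lower numbers for an effect already at smaller amounts:

Compound 1 `Cc1cc(C(=O)O)ccc1CN1CCC[C@H](O[C@H](CO)c2cc(Cl)cc(Cl)c2)[C@@H]1c1cccc(F)c1`: 12000 nM
Compound 2 `OC[C@@H](O[C@H]1CCCN(Cc2ncc[nH]2)[C@H]1c1ccccc1)c1cc(Cl)cc(Cl)c1`: 47000 nM

Of these two numbers, compound 2 carries the higher one. Among the measured compounds shown here, compound 1, the only neighbour for comparison, differs from it in more than one place, so no single step connects them; their two values simply show that compound 1 sits at the lower number and compound 2 at the higher, and that gap lies beyond the scatter of this assay.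

The compound still to be measured, compound 3 `O=C(O)c1ccc(CN2CCC[C@H](O[C@H](CO)c3cc(Cl)cc(Cl)c3)[C@@H]2c2ccccc2)c([N+](=O)[O-])c1`, is reached from compound 2 by one change: 4-carboxy-2-nitrophenyl in place of 1H-imidazol-2-yl on a saturated chain carbon bound to an amine nitrogen in a ring. Compound 3 thus keeps the unsubstituted phenyl of compound 2 while taking up a carboxy-bearing benzyl group on the ring nitrogen, a feature shared with compound 1.

Because compound 1 gives 12000 nM in this assay with such a carboxy-bearing group in the same place, compound 3 is expected to move toward a lower number, and the estimated step of a 3.1-fold lower number from compound 2 to compound 3 (0.50 log units; beyond the scatter) is expected to exceed the scatter. The estimate for compound 3 is 15000 nM, with a range from 5000 nM to 50000 nM.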

Compound 3, half-maximal effective concentration: 520 nM
Beside the measured number, compound 3's estimate is 29-fold (1.46 log units) above it, and the stated range ends above it.
By their numbers in this assay, from the lowest: compound 3; then compound 1; then compound 2.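

The place on a saturated chain carbon bound to an amine nitrogen in a ring now has its first single-change reading: in this assay, 4-carboxy-2-nitrophenyl in place of 1H-imidazol-2-yl gives a 90-fold lower number from compound 2 to compound 3 (1.96 log units; beyond the scatter), a large step, so the group at this place can shift the number strongly while the rest of the molecule stays the same. The step belongs to the exchange as a whole, as the entering group replaces a five-membered aromatic ring with 2 hetero atoms by a six-membered aromatic ring of carbon only and also brings the carboxy and nitro groups with it. Nothing measured here bears on why the number falls so far.

How the step divides among these parts stays open, and a 4-carboxyphenyl group and a 2-nitrophenyl group at this place would each test one part without the other. As far as these compounds go, it also remains open whether a tetrazole or a primary amide could stand in for the carboxylic acid, and whether a chlorine, a nitrile or a methoxy group could stand in for the nitro group, with the unsubstituted phenyl of compound 3 kept in place.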